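Chain Lengthening on a Shared Naphthoquinone-Type Core

This account rests on a few compounds, and the source may have more. Where it says the series, first, only, none or still open, it means among the compounds named here.

Three compounds sharing one core were measured in a functional assay on KB cells (Homo sapiens) for cytotoxicity, read by resazurin assay, with a stated time of 3 days; on this read-out lower numbers stand for stronger inhibition and higher numbers for weaker inhibition. Compound 1 `CCCCCCC(=O)NCC(C)(C)CC1=C(O)C(=O)c2ccccc2C1=O` gives 28200 nM, and compound 2 `CCCCCCCCC(=O)NCC(C)(C)CC1=C(O)C(=O)c2ccccc2C1=O` gives 19700 nM. The change between them is ethyl in place of hydrogen on a saturated chain carbon, six bonds along the chain from a carbonyl carbon and the step is a 1.4-fold lower number from compound 1 to compound 2 (0.16 log units; within the scatter). Compound 3 `CCCCCCCCCCCC(=O)OCC(C)(C)CC1=C(O)C(=O)c2ccccc2C1=O` gives 35700 nM in this assay; how its core differs from that of compound 1 is not broken down here. Compound 4 `CCCCCCCCCCCCCC(=O)OCC(C)(C)CC1=C(O)C(=O)c2ccccc2C1=O` is not yet measured; it differs from compound 3 by ethyl in place of hydrogen on a saturated chain carbon, ten or more bonds along the chain from a carbonyl carbon. This is the same kind of change as that from compound 1 to compound 2, though at a different place along the chain. Since the earlier step was a 1.4-fold lower number from compound 1 to compound 2 (0.16 log units; within the scatter), the step is expected to be a 1.3-fold lower number from compound 3 to compound 4 (0.11 log units; within the scatter). Compound 4 is therefore estimated at 28000 nM, between 12000 nM and 70000 nM.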

Compound 4, half-maximal inhibitory concentration: 51400 nM
Estimate against measurement, compound 4: 1.8-fold (0.26 log units) below, within the range that was stated.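

In this assay, ethyl in place of hydrogen on a saturated chain carbon, ten or more bonds along the chain from a carbonyl carbon, gives a 1.4-fold higher number from compound 3 to compound 4 (0.16 log units; within the scatter). Set beside the earlier step on the other core, the two steps have opposite signs, yet the gap between them does not exceed the scatter: the same change on two cores in this assay, a 1.4-fold lower number (0.16 log units; within the scatter) from compound 1 to compound 2 and a 1.4-fold higher number (0.16 log units; within the scatter) from compound 3 to compound 4, 2.1-fold (0.31 log units) apart, within the scatter of two such steps. This shows no difference in how the change carries from one core to the other, but it does not show that the change has any effect on either core, or that the two cores respond alike.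

Going by these compounds, whether a much longer chain, or a chain ending in an amine or a carboxylic acid, would move the number beyond the scatter stays open. Also open, on these data alone, is how the amide and the ester linkage compare on chains of the same length.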